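A second methoxy on the amide aryl ring

The source may report more compounds than this note shows. Statements on the series, on what has been measured and on what is new or still open speak of the compounds shown alone.

Three amides built on one shared core have been tested in a functional assay on MDA-MB-231 cells (Homo sapiens) for antiproliferative activity, read by CCK-8 assay, with a stated time of 72 h; on this read-out higher numbers stand for weaker inhibition and lower numbers for stronger inhibition. Compound 1 `O=C(Nc1cccc(-c2oc3cc(-c4ccc(F)cc4)ccc3c(=O)c2O)c1)c1ccc(F)cc1` gives 16000 nM. Compound 2 `O=C(Nc1cccc(-c2oc3cc(-c4ccc(F)cc4)ccc3c(=O)c2O)c1)c1ccc(Cl)cc1` gives 12800 nM, and compound 3 `COc1cccc(C(=O)Nc2cccc(-c3oc4cc(-c5ccc(F)cc5)ccc4c(=O)c3O)c2)c1` gives 9160 nM. Compound 3 carries the lowest of the three numbers, yet neither of its steps from the other two leaves the scatter: a 1.7-fold lower number from compound 1 to compound 3 (0.24 log units; within the scatter), and a 1.4-fold lower number from compound 2 to compound 3 (0.15 log units; within the scatter). The exchange of the halogen on the amide aryl ring, a 1.3-fold lower number from compound 1 to compound 2 (0.10 log units; within the scatter), is likewise within the scatter, so the three compounds are not separated in this assay.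

Compound 4 `COc1cc(OC)cc(C(=O)Nc2cccc(-c3oc4cc(-c5ccc(F)cc5)ccc4c(=O)c3O)c2)c1` differs from compound 3 by methoxy in place of hydrogen on an aromatic carbon. Among the compounds with values here, no measured step adds a group to the amide aryl ring while keeping the rest in place; the two steps that touch that ring, a 1.7-fold lower number from compound 1 to compound 3 (0.24 log units; within the scatter) and a 1.4-fold lower number from compound 2 to compound 3 (0.15 log units; within the scatter), replace it whole and stay within the scatter. The three numbers therefore give no ground to expect a shift beyond the scatter in this assay, in either direction.

Compound 4 is expected to give about 8000 nM in this assay, within a range from 3500 nM to 18000 nM. The step this estimate implies is a 1.1-fold lower number from compound 3 to compound 4 (0.06 log units; within the scatter), which is expected to lie inside the scatter.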

Compound 4, half-maximal inhibitory concentration: 4040 nM
The estimate for compound 4 lay 2.0-fold (0.30 log units) above the measured number; low and high end bracket the measured number.
By their numbers in this assay, from the lowest: compound 4; then compounds 3, 2 and 1 (each within the scatter of the next).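

In this assay, within the data shown here, methoxy in place of hydrogen on the 3-methoxyphenyl group gives a 2.3-fold lower number from compound 3 to compound 4 (0.36 log units; beyond the scatter), the first change on the amide aryl ring that leaves the scatter. The 3,5-dimethoxyphenyl group also stands apart from both halogenated rings, with a 3.2-fold lower number from compound 2 to compound 4 (0.50 log units; beyond the scatter) and a 4.0-fold lower number from compound 1 to compound 4 (0.60 log units; beyond the scatter), so compound 4 is the only one of the four whose steps to all the others lie beyond the scatter, although each of these steps is modest. The ring position meta to a large group and meta to a methoxy group therefore responds to this change in a way the exchanges among the first three amides did not show, but nothing at hand accounts for the shift.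

The compounds shown carry only methoxy, fluoro and chloro on this ring, which leaves open how a hydroxyl, an amine or a longer alkoxy chain at the same position would compare with methoxy. Also open, as far as these compounds go, is whether methoxy in place of hydrogen would give a similar step on the 4-fluorophenyl ring of compound 1 or the 4-chlorophenyl ring of compound 2.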